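The source may report more compounds than this note shows. Statements on the series, on what has been measured and on what is new or still open speak of the compounds shown alone.

Compound 1 `CCOC(=O)CSCc1nc2cc([N+](=O)[O-])ccc2[nH]1`: in a functional assay on HCT-116 cells (Homo sapiens) for cytotoxicity, read by MTT assay, with a stated time of 48 h (a higher number here means a weaker inhibitor, a lower number a stronger inhibitor), compound 1 gives > 100000 nM, which is a limit of the assay.
Compound 2 `NC(=O)CSCc1nc2cc([N+](=O)[O-])ccc2[nH]1`: in this assay compound 2 gives 17200 nM.

Within the data shown here, compound 2 holds the only real number here; the other value is a limit. Among the measured compounds shown here, the one measured step, an at least 5.8-fold lower number from compound 1 to compound 2 (0.76 log units; beyond the scatter), shows that exchanging the group on the carbonyl carbon can shift the number. Compound 3 `CC1=NN(C(=O)CSCc2nc3cc([N+](=O)[O-])ccc3[nH]2)C(=O)C1` carries a group of 7 heavy atoms (4 carbon, 2 nitrogen, 1 oxygen; one five-membered non-aromatic ring with 2 hetero atoms) in place of one nitrogen atom, on a carbonyl carbon. For the measured compounds named here, that earlier step is the only guide, and it does not tell which way this larger exchange will go, so compound 3 is expected to stay near compound 2, with a 1.4-fold lower number from compound 2 to compound 3 (0.16 log units; within the scatter) as the expected step. The estimate for compound 3 is 12000 nM, within 2500 nM to 60000 nM.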

Compound 3, half-maximal inhibitory concentration: 5410 nM
Estimate against measurement, compound 3: 2.2-fold (0.35 log units) above; low and high end bracket the measured number.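

In this assay, the group on the carbonyl carbon now gives a change read between two real numbers, a 3.2-fold lower number from compound 2 to compound 3 (0.50 log units; beyond the scatter), so the lower number does not end with the amino group. The five-membered ring group also stands far from ethoxy, with an at least 18-fold lower number from compound 1 to compound 3 (1.26 log units; beyond the scatter). That step has no exact size, since compound 1 stands at a limit: the limit of > 100000 nM in this assay, at which 1 of the 3 values shown sits.

Which part of the ring group goes with the lower number stays open. So does how a simple methylamine or a carboxylic acid on the same carbonyl carbon would compare.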